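The compounds below may be only part of what the source reports. "The series", "measured", "known", "first", "only" and "open" are said of these compounds alone.

Working notes on the series in an ADME assay on HepG2 2.2.15 cells (Homo sapiens) for cytotoxicity; on this read-out lower numbers stand for higher toxicity in this test and higher numbers for lower toxicity in this test.

Compound 1 `CC(C)(C)OC(=O)Nc1ncc(C(Oc2cccc(C#N)c2)c2ccc(Cl)cc2)s1` carries the shared core with a tert-butoxycarbonyl amine. In this assay compound 1 gives > 50000 nM, which is a limit of the test rather than a number. Compound 2 `Clc1ccc(C(Oc2ccc3cc(Br)ccc3c2)c2cnc(NCC3CCCCC3)s2)cc1` is reported in this assay only as "not toxic" (no number reported), with no value given; it therefore stands at the non-toxic end of the series alongside compound 1, as the limit of > 50000 nM in this assay, at which 1 of the 2 values shown sits, shows for the one numerical entry.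

Compound 3 `O=C(Nc1ncc(C(Oc2ccc3cc(Br)ccc3c2)c2ccc(Cl)cc2)s1)C1CCOCC1` differs from compound 2 in one place: (oxan-4-yl)carbonyl in place of cyclohexylmethyl on a nitrogen on an aromatic ring. Among the compounds with values here, no measured step between compounds covers this exchange, and the amide and carbamate on the ring nitrogen of compound 1 sit at the limit. The step from compound 2 to compound 3 in this assay is expected to be none beyond the scatter. Compound 3 is therefore expected to give about 50000 nM in this assay, between 20000 nM and 100000 nM, most likely as a limit again.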

Compound 3, half-maximal cytotoxic concentration: "not toxic" (no number reported)
The entry for compound 3 holds no number, so the estimate cannot be set against anything.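

Compound 2 and compound 3 are both entered in this assay only as "not toxic", without a number, so no step can be read between them. The compounds shown leave open whether exchanging cyclohexylmethyl for (oxan-4-yl)carbonyl changes the read-out at all, as the only figure is a limit: the limit of > 50000 nM in this assay, at which 1 of the 3 values shown sits.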